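The source may report more compounds than this note shows. Statements on the series, on what has been measured and on what is new or still open speak of the compounds shown alone.

Compound 2 `O=C(Nc1cccc(-c2oc3cc(-c4ccc(F)cc4)ccc3c(=O)c2O)c1)c1cc(F)cc(F)c1` gives 2440 nM in a functional assay on MDA-MB-231 cells (Homo sapiens) for antiproliferative activity, read by CCK-8 assay, with a stated time of 72 h (on this read-out lower numbers stand for stronger inhibition and higher numbers for weaker inhibition), the lowest of the two numbers in hand; compound 1 `CCc1ccc(C(=O)Nc2cccc(-c3oc4cc(-c5ccc(F)cc5)ccc4c(=O)c3O)c2)cc1` gives 9070 nM in this assay. Going by the values given here, the one measured step runs toward compound 2, a 3,5-difluorophenyl replacing a 4-ethylphenyl, and it read a 3.7-fold lower number from compound 1 to compound 2 (0.57 log units; beyond the scatter). Compound 3 `CCCc1ccc(C(=O)Nc2cccc(-c3oc4cc(-c5ccc(F)cc5)ccc4c(=O)c3O)c2)cc1` reverses that direction with a longer chain: 4-propylphenyl in place of 3,5-difluorophenyl on a carbonyl carbon. Since compound 1 sits at 9070 nM, compound 3 is expected to return to a higher number of similar size, an expected step of a 3.1-fold higher number from compound 2 to compound 3 (0.49 log units; beyond the scatter). The estimate for compound 3 in this assay is 7500 nM, within 2500 nM to 20000 nM.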

Compound 3, half-maximal inhibitory concentration: 32200 nM
Compound 3: the middle estimate sits 4.3-fold (0.63 log units) below what was measured, outside the stated range (above it).
By their numbers in this assay, from the lowest: compound 2; then compound 1; then compound 3.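

At this carbonyl carbon, 4-propylphenyl in place of 3,5-difluorophenyl gives a 13-fold higher number from compound 2 to compound 3 (1.12 log units; beyond the scatter) in this assay and opens a wider gap than 4-ethylphenyl did. Chain length alone also matters here: methyl in place of hydrogen on the saturated chain gives a 3.6-fold higher number from compound 1 to compound 3 (0.55 log units; beyond the scatter) and shows that this single added carbon is enough to move the number beyond the scatter. No measurement on hand accounts for this change.

Going by these compounds, whether a butyl chain would raise the number further remains open. So does the effect of an amine or a carboxylic acid on this aromatic ring.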